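The source may hold more compounds than are shown below. What is called first, only, known or untested is meant among the compounds shown, and "the series" means these compounds.

Among the compounds with values here, compound 2 `COc1cc2c(Oc3c(F)cc(NC(=O)NN4C(=O)CCSC4c4c(F)cccc4F)cc3F)ccnc2cc1OCCCN1CCC(C)CC1` gives 1630 nM in a functional assay on A549 cells (Homo sapiens) for antiproliferative activity, read by MTT assay, with a stated time of 72 h (a higher number here means a weaker inhibitor, a lower number a stronger inhibitor), the highest of the two numbers so far. Its nearest point is compound 1 `COc1cc2c(Oc3c(F)cc(NC(=O)NN4C(=O)CCSC4c4c(F)cccc4F)cc3F)ccnc2cc1OCCCN1CCCC1`, which gives 400 nM in this assay. Within the data shown here, the one measured step at this position, a 4.1-fold higher number from compound 1 to compound 2 (0.61 log units; beyond the scatter), is the only guide available. Compound 3 `COc1cc2c(Oc3c(F)cc(NC(=O)NN4C(=O)CCSC4c4c(F)cccc4F)cc3F)ccnc2cc1OCCCN1C[C@H]2CCCC[C@H]2C1` carries a group of 9 heavy atoms (8 carbon, 1 nitrogen; one five-membered non-aromatic ring with 1 hetero atom, one six-membered non-aromatic ring of carbon only) in place of a group of 7 heavy atoms (6 carbon, 1 nitrogen; one six-membered non-aromatic ring with 1 hetero atom), on a saturated chain carbon, three bonds along the chain from an oxygen on an aromatic ring. Among the measured compounds shown here, since the single prior step at this position went modestly toward a higher number, a step of similar size in the same direction, or none beyond the scatter, is expected for compound 3, a 1.2-fold higher number from compound 2 to compound 3 (0.09 log units; within the scatter). Compound 3 is accordingly estimated at 2000 nM, range 600 nM to 7000 nM.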

Compound 3, half-maximal inhibitory concentration: 3610 nM
Beside the measured number, compound 3's estimate is 1.8-fold (0.26 log units) below it; the measured number falls inside the stated range.
By their numbers in this assay, from the lowest: compound 1; then compound 2; then compound 3.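

The group of 9 heavy atoms, with its five-membered and six-membered rings, extends the rise at this position in this assay: a 2.2-fold higher number from compound 2 to compound 3 (0.35 log units; beyond the scatter), and a 9.0-fold higher number from compound 1 to compound 3 (0.96 log units; beyond the scatter). Among these compounds the number climbs with each larger group, from 5 to 7 to 9 heavy atoms, and none goes against this order. No measurement here bears on the reason for the rise.

On these data alone, whether the order holds for a smaller azetidine, or for a morpholine with its ring oxygen, remains open. As far as these compounds go, the effect of the 2 defined stereocentres of compound 3 also remains open.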